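The compounds below may be only part of what the source reports. "The series", "measured", "known", "first", "only" and "open" are said of these compounds alone.

Measured compounds:
- compound 1 `Cn1c(N2CCCC2)c(C#N)c2c(N)ncnc21` — in an assay on isolated protein for binding affinity to Leucine-rich repeat serine/threonine-protein kinase 2 (Homo sapiens), read by TR-FRET and LanthaScreen, with a stated time of 2 h (a higher number here means a weaker inhibitor, a lower number a stronger inhibitor), compound 1 gives 41 nM
- compound 2 `C[C@@H]1CCCN1c1c(C(N)=O)c2c(N)ncnc2n1C` — in this assay compound 2 gives 77 nM

Compound 1 stands at the lowest of the two numbers, but compound 2 sits within the scatter of it, so the two values show no order between them. Within the data shown here, compound 2 differs from compound 1 in more than one place, and no single step can be drawn from their pair.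

Compound 3 `C[C@H]1CCCN1c1c(C#N)c2c(N)ncnc2n1C` has not yet been measured in this assay. It differs from compound 1 by methyl in place of hydrogen on a saturated ring carbon; in words, methyl in place of hydrogen on a saturated ring carbon, with the rest of the molecule kept as in compound 1. Among the measured compounds shown here, no measured pair shows this change on its own. For the measured compounds named here, the only hint is compound 2, which also carries the methyl on the ring and gives 77 nM, a number within the scatter of compound 1. The step from compound 1 to compound 3 is therefore expected to be small, a 1.2-fold higher number from compound 1 to compound 3 (0.09 log units; within the scatter), with no direction beyond the scatter. Compound 3 is estimated at 50 nM, in a range from 15 nM to 160 nM.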

Compound 3, inhibition constant: 136 nM
Beside the measured number, compound 3's estimate is 2.7-fold (0.43 log units) below it; measured number inside the range.
By their numbers in this assay, from the lowest: compounds 1, 2 and 3 (each within the scatter of the next, the first and the last beyond it).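

In this assay, methyl in place of hydrogen on a saturated ring carbon, next to the ring nitrogen, turns pyrrolidin-1-yl into 2-methylpyrrolidin-1-yl and gives a 3.3-fold higher number from compound 1 to compound 3 (0.52 log units; beyond the scatter) with the rest of the molecule kept. This is the only single change that can be read on its own among these compounds, and it shows that this ring carbon is not indifferent to substitution: one added heavy atom moves the number beyond the scatter, modestly, towards a weaker inhibitor. Nothing available accounts for why this methyl weakens binding.

Among the compounds shown, the methyl occurs with the nitrile in a single spatial arrangement, so it remains open whether its mirror-image form would give the same step. Also open, from the compounds shown here alone, is how other groups on this carbon, such as ethyl, hydroxymethyl or a fluorine atom, would read, and whether a methyl would give a similar step where the nitrile is replaced by the primary amide of compound 2.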